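This account rests on a few compounds, and the source may have more. Where it says the series, first, only, none or still open, it means among the compounds named here.

Compound 1 `CNC(=O)c1ccc(Oc2cccc(NC(=S)Nc3ccc(Cl)cc3)c2)nc1`: 66500 nM
Compound 2 `CNC(=O)c1ccc(Oc2cccc(NC(=S)Nc3ccc(F)c(F)c3)c2)nc1`: 69300 nM
Compound 3 `CNC(=O)c1ccc(Oc2cccc(NC(=S)Nc3ccc(F)c(C(F)(F)F)c3)c2)nc1`: 13300 nM

All three share one core and differ only in the aryl group attached to the thiourea nitrogen. In a functional assay on MDA-MB-231 cells (Homo sapiens) for antiproliferative activity, read by MTT assay (on this read-out lower numbers stand for stronger inhibition and higher numbers for weaker inhibition), compound 1 gives 66500 nM, and compound 2 gives 69300 nM; the step of a 1.0-fold higher number from compound 1 to compound 2 (0.02 log units; within the scatter) lies within the scatter, so these two cannot be told apart. Among the compounds with values here, compound 3 stands clearly apart from both: it gives 13300 nM, and the step of a 5.2-fold lower number from compound 2 to compound 3 (0.72 log units; beyond the scatter) is the only change among the measured compounds that moved the number beyond the scatter.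

Compound 4 `CNC(=O)c1ccc(Oc2cccc(NC(=S)Nc3cccc(C(F)(F)F)c3)c2)nc1` has not yet been measured. It differs from compound 1 in one place: 3-(trifluoromethyl)phenyl in place of 4-chlorophenyl on an amide-type nitrogen. Within the data shown here, two measured steps bear on this change. The swap of one halogenated phenyl for another, a 1.0-fold higher number from compound 1 to compound 2 (0.02 log units; within the scatter), changed nothing that can be trusted. Adding a trifluoromethyl group, a 5.2-fold lower number from compound 2 to compound 3 (0.72 log units; beyond the scatter), gave a modestly lower number. Compound 4 carries a trifluoromethyl group but lacks the fluoro that compound 3 also carries, so a downward step is expected, but a smaller one than from compound 2 to compound 3. For compound 4 the expected step is a 3.0-fold lower number from compound 1 to compound 4 (0.48 log units; beyond the scatter). Compound 4 is therefore estimated at 22000 nM, with a likely range from 8000 nM to 55000 nM.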

Compound 4, half-maximal inhibitory concentration: 38100 nM
Compound 4: the middle estimate sits 1.7-fold (0.24 log units) below what was measured; low and high end bracket the measured number.
By their numbers in this assay, from the lowest: compound 3; then compounds 4, 1 and 2 (each within the scatter of the next).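

In this assay, within the data shown here, the trifluoromethyl group without the fluoro gives no step that can be trusted: 3-(trifluoromethyl)phenyl cannot be told apart from 4-chlorophenyl, a 1.7-fold lower number from compound 1 to compound 4 (0.24 log units; within the scatter), or from 3,4-difluorophenyl, a 1.8-fold lower number from compound 2 to compound 4 (0.26 log units; within the scatter). The fluoro of compound 3 is what separates the two trifluoromethyl compounds, since putting hydrogen in its place gives a 2.9-fold higher number from compound 3 to compound 4 (0.46 log units; beyond the scatter), so the standing of compound 3 belongs to the two groups together and not to the trifluoromethyl group alone. Nothing available here gives a reason why this one fluoro counts for so much.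

The compounds shown leave open whether the fluoro is needed as such, or whether another group in its place on compound 3, such as a methoxy group, an amine or a nitrile, would hold the number or move it further. They also leave open whether the same pattern would survive a carbonyl in place of the thiocarbonyl, as every compound here keeps the thiourea link and the rest of the shared core unchanged.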